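A few compounds are considered here, and "the series" means these few. Any claim that something is new, unique, unknown or untested is made for them only; others in the source may bear on it.

In a functional assay on HL-60 cells (Homo sapiens) for inhibition, read by CCK-8 assay, with a stated time of 48 h (on this read-out lower numbers stand for stronger inhibition and higher numbers for weaker inhibition), compound 1 `Nc1ccc(Oc2ccccc2-c2ccc(S(=O)(=O)NCCNC(=O)Nc3ccc(Cl)cc3)s2)cc1` gives > 50000 nM, which is a limit of the assay and not a number. Compound 1 therefore stands at the limit of > 50000 nM in this assay, at which 2 of the 3 values shown sit. Compound 2 `COc1ccc(Oc2ccccc2-c2ccsc2S(=O)(=O)N2CCN(C(=O)Nc3cccc([N+](=O)[O-])c3)CC2)cc1OC` gives > 50000 nM, and this too is a limit. Compound 3 `O=C(Nc1ccc(F)cc1)N1CCN(S(=O)(=O)c2sccc2-c2ccccc2Oc2ccc(O)c(O)c2)CC1` is the only one of the three with a number, 8100 nM.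

The next compound to be tested is compound 4 `O=C(NCCNS(=O)(=O)c1ccc(-c2ccccc2Oc2ccc([N+](=O)[O-])c([N+](=O)[O-])c2)s1)Nc1ccc(Cl)cc1`. It keeps the core of compound 1 but carries 3,4-dinitrophenyl in place of 4-aminophenyl on an oxygen on an aromatic ring.

Among the measured compounds shown here, no two measured compounds differ in one place only, so the effect of this change has not been measured. Compound 3, at 8100 nM, shows that a measurable value can occur in this small set, although it differs from compound 1 in more than one place. In this assay, only a modest shift toward stronger inhibition is therefore expected, and compound 4 may well remain weak. The estimated change is an at least 1.2-fold lower number from compound 1 to compound 4 (0.09 log units; that floor lies within the scatter). For compound 4, the estimated value is 40000 nM, with an expected range from 12000 nM to 80000 nM.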

Compound 4, half-maximal inhibitory concentration: 8100 nM
Estimate against measurement, compound 4: 4.9-fold (0.69 log units) above; measured number below the stated range.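

In this assay, among the compounds shown here, 3,4-dinitrophenyl in place of 4-aminophenyl on an oxygen on an aromatic ring gives the first step in this set that can be read for a single change: an at least 6.1-fold lower number from compound 1 to compound 4 (0.79 log units; beyond the scatter). The earlier compounds shown here differed from one another in more than one place, so they could not show that a change at this position alone, on the core of compound 1, can move the result beyond the scatter. Compound 1 carries a limit of the assay and not a number, so the printed size of the step is only a floor: the limit of > 50000 nM in this assay, at which 2 of the 4 values shown sit.

The compounds shown leave open whether the step belongs to the 3,4-dinitrophenyl group as a whole or could be reached with a phenyl carrying one nitro group, and where a carboxylic acid or a nitrile at this same place would fall. They also leave open whether the same change would have a similar effect on the core of compound 2 or of compound 3, which differ from compound 1 in more than one place.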